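A few compounds are considered here, and "the series" means these few. Any claim that something is new, unique, unknown or untested is made for them only; others in the source may bear on it.

Among the compounds with values here, in a functional assay on HeLa cells (Homo sapiens) for inhibition, read by MTT assay, with a stated time of 24 h (a higher number here means a weaker inhibitor, a lower number a stronger inhibitor), compound 1 `CCOC(=O)C1=Cc2ccccc2OC1(OCc1cn(CC(=O)Nc2cccc(Cl)c2)nn1)C(F)(F)F` gives 12300 nM, and this is the only actual number among the three measured compounds. Compound 2 `CCOC(=O)C1=Cc2ccccc2OC1(OCc1cc(-c2ccc(C)cc2)no1)C(F)(F)F` reaches only a limit of this assay, > 150000 nM. Compound 3 `O=C(O)C1=Cc2ccccc2OC1(OCc1cc(-c2ccc(F)cc2)no1)C(F)(F)F` likewise reaches only a limit, > 150000 nM. There is, then, (the limit of > 150000 nM in this assay, at which 2 of the 3 values shown sit), and compound 1 stands alone with a measured value. Compound 4 `CCOC(=O)C1=Cc2ccccc2OC1(OCc1cn(-c2ccc(F)c(Cl)c2)nn1)C(F)(F)F` has not yet been measured; it differs from compound 1 in one place: 3-chloro-4-fluorophenyl in place of ((3-chlorophenyl)carbamoyl)methyl on an aromatic nitrogen. Within the data shown here, no pair of measured compounds shows a step of this kind, so the data give no direction for it. The step from compound 1 to compound 4 is expected to be a 1.6-fold higher number from compound 1 to compound 4 (0.21 log units; within the scatter), a modest shift toward weaker inhibition. Compound 4 is expected to give 20000 nM, somewhere between 5000 nM and 80000 nM.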

Compound 4, half-maximal inhibitory concentration: 22700 nM
Compound 4: the middle estimate sits 1.1-fold (0.05 log units) below what was measured; the range from low to high includes it.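

In this assay, putting 3-chloro-4-fluorophenyl in place of ((3-chlorophenyl)carbamoyl)methyl on an aromatic nitrogen gives a 1.8-fold higher number from compound 1 to compound 4 (0.27 log units; within the scatter). This only measured step shows that this nitrogen can carry a phenyl ring directly, with no amide hydrogen or carbonyl in the group, and the read-out cannot be told apart from that of the larger group. No measurement shown gives a cause for this.

Still open, from the compounds shown here alone, is how a plain phenyl, with neither chlorine nor fluorine, would read here. A group of another kind on this nitrogen, such as a carboxylic acid or an amine on a longer chain, also remains untested among the compounds shown.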